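Swapping the benzyl aryl group in a sulfonyl guanidine series

A few compounds are considered here, and "the series" means these few. Any claim that something is new, unique, unknown or untested is made for them only; others in the source may bear on it.

Measured compounds:
- compound 1 `C/C(C#Cc1ccccc1)=N\N/C(N)=N/S(=O)(=O)c1cc(C)c(Cl)cc1SCc1ccc(C)cc1`: 125000 nM
- compound 2 `Cc1cc(S(=O)(=O)/N=C(\N)N/N=C/C#Cc2ccccc2)c(SCc2ccc(C(F)(F)F)cc2)cc1Cl`: 105000 nM
- compound 3 `Cc1cc(S(=O)(=O)/N=C(\N)N/N=C/C#Cc2ccccc2)c(SCc2ccc(Cl)cc2)cc1Cl`: 18000 nM

In a functional assay on MCF7 cells (Homo sapiens) for antiproliferative activity, read by MTT assay, with a stated time of 72 h (a higher number here means a weaker inhibitor, a lower number a stronger inhibitor), compound 1 gives the highest of the three numbers; compound 2 lies within the scatter of it, while compound 3 stands well apart. The unmeasured compound 4 `C/C(C#Cc1ccccc1)=N\N/C(N)=N/S(=O)(=O)c1cc(C)c(Cl)cc1SCc1cccc2ccccc12` differs from compound 1 by naphthalen-1-yl in place of 4-methylphenyl on a saturated chain carbon bound to a sulfur. Among the compounds with values here, no measured step matches this change directly. The nearest guide is a 5.8-fold lower number from compound 2 to compound 3 (0.77 log units; beyond the scatter), which shows that changing the group on the aryl ring of the benzyl sulfide can move the number modestly. For compound 4 a modest lowering is therefore expected, a 2.1-fold lower number from compound 1 to compound 4 (0.32 log units; beyond the scatter), though the direction is uncertain. The estimate for compound 4 is 60000 nM, with a range from 15000 nM to 200000 nM.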

Compound 4, half-maximal inhibitory concentration: 210000 nM
The estimate for compound 4 lay 3.5-fold (0.54 log units) below the measured number, outside the stated range (above it).
By their numbers in this assay, from the lowest: compound 3; then compounds 2, 1 and 4 (each within the scatter of the next).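

Replacing 4-methylphenyl with naphthalen-1-yl at this saturated chain carbon bound to a sulfur adds a second six-membered aromatic ring, yet this assay shows a 1.7-fold higher number from compound 1 to compound 4 (0.23 log units; within the scatter), so the two compounds cannot be told apart here. This position therefore accepts this change of aryl group with no clear shift in the number. Nothing available explains this result. Still open, going by these compounds, is whether 4-chlorophenyl at this position would give a lower number in the core of compound 1. Also open, on these data alone, is how a phenyl ring bearing an amine or a carboxylic acid would read.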